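A few compounds are considered here, and "the series" means these few. Any claim that something is new, unique, unknown or untested is made for them only; others in the source may bear on it.

Compound 1 `COc1ccccc1NC(=O)c1c(NO)cc(-c2ccccc2)oc1=O` and compound 2 `COc1cccc(NC(=O)c2c(NO)cc(-c3ccccc3)oc2=O)c1` share one core and differ only in where a methoxy group sits on the amide-bearing ring. In an ADME assay on Huh-7 cells (Homo sapiens) for cytotoxicity, with a stated time of 3 days (a lower number here means that less compound is tolerated, a higher number that more compound is tolerated), compound 1 reaches only the limit of the test, > 20000 nM. In this assay compound 2 likewise reaches only the limit, > 20000 nM. Among the compounds with values here, the one step measured, a step that the two limits leave unreadable from compound 1 to compound 2, therefore cannot be read in size or direction, because of the limit of > 20000 nM in this assay, at which 2 of the 2 values shown sit. Within the data shown here, compound 2 thus stands at the limit, with no number of its own; its value and the one other value shown are both limits.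

Compound 3 `O=C(Nc1cccc(C(F)(F)F)c1)c1c(NO)cc(-c2ccccc2)oc1=O` is the next compound, reached from compound 2 by the change (trifluoromethyl in place of methoxy on an aromatic carbon). Among the measured compounds shown here, no measured step speaks to swapping a methoxy for a trifluoromethyl here, so nothing in the data points to a step beyond the scatter in either direction. The expectation for compound 3 is therefore that this assay again reports a limit rather than a number, with an estimated value of 25000 nM, in a range from 8000 nM to 60000 nM. The expected step is a step that the limit leaves unreadable from compound 2 to compound 3, which is expected to be read as no change.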

Compound 3, half-maximal cytotoxic concentration: 19000 nM
Compound 3: the middle estimate sits 1.3-fold (0.12 log units) above what was measured, and the stated range covers the measured number.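

Compound 2 gives only a limit, > 20000 nM. In this assay compound 3 gives 19000 nM, so with trifluoromethyl in place of methoxy on this aromatic carbon, the compounds shown yield a true measured cytotoxic concentration for the first time. The change amounts to an at least 1.0-fold lower number from compound 2 to compound 3 (0.02 log units; that floor lies within the scatter), and this is only a floor rather than a full size, because one end of the step is a limit and not a number: the limit of > 20000 nM in this assay, at which 2 of the 3 values shown sit.

As far as these compounds go, how far compound 3 really lies from compound 2 remains unknown, and the floor alone does not establish that this swap lowers the number at all. Also open, from the compounds shown here alone, is how other groups on the same aromatic carbon, such as an amine, a nitrile or a carboxylic acid, would read in this assay, and whether they would give a number, as compound 3 does, or only a limit.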